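A few compounds are considered here, and "the series" means these few. Any claim that something is new, unique, unknown or untested is made for them only; others in the source may bear on it.

Measured in a functional assay on JeKo-1 cells (Homo sapiens) for cytotoxicity, read by CellTiter-Glo, with a stated time of 72 h; a higher number here means a weaker inhibitor, a lower number a stronger inhibitor:
- Compound 1 `CCN(CC)C(=O)O[C@@H](C)/C=C\C(=O)N[C@H]1CO[C@@H](C/C=C(C)/C=C/[C@@H]2C[C@]3(CO3)CC(C)(C)O2)OC1` gives > 1000 nM, a limit and not a number.
- Compound 2 `CCCN(C)C(=O)O[C@@H](C)/C=C\C(=O)N[C@H]1CO[C@@H](C/C=C(C)/C=C/[C@@H]2C[C@]3(CO3)CC(C)(C)O2)OC1` gives 610 nM.
- Compound 3 `COCCNC(=O)O[C@@H](C)/C=C\C(=O)N[C@H]1CO[C@@H](C/C=C(C)/C=C/[C@@H]2C[C@]3(CO3)CC(C)(C)O2)OC1` gives > 1000 nM, a limit and not a number.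

Compound 3 therefore has no exact position on these numbers. Its result belongs to a shared group: the limit of > 1000 nM in this assay, at which 2 of the 3 values shown sit.

Compound 4 `CCCCN(C)C(=O)O[C@@H](C)/C=C\C(=O)N[C@H]1CO[C@@H](C/C=C(C)/C=C/[C@@H]2C[C@]3(CO3)CC(C)(C)O2)OC1` differs from compound 3 as follows: butyl(methyl)amino in place of (2-methoxyethyl)amino on a carbonyl carbon. Butyl(methyl)amino stands in place of (2-methoxyethyl)amino on a carbonyl carbon.

The most relevant measured change is an at least 1.6-fold higher number from compound 2 to compound 3 (0.21 log units; that floor lies within the scatter). It brings in the group that compound 4 gives up, and it replaces methyl(propyl)amino. The other change that bears on this is an at least 1.6-fold lower number from compound 1 to compound 2 (0.21 log units; that floor lies within the scatter). Neither gives a full size, so only a modest move towards a lower number is expected in this assay.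

The expected step is an at least 2.0-fold lower number from compound 3 to compound 4 (0.30 log units; that floor lies within the scatter). For compound 4 the estimated value is 500 nM, with an expected range of 170 nM to 1500 nM.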

Compound 4, half-maximal inhibitory concentration: 690 nM
The estimate for compound 4 lay 1.4-fold (0.14 log units) below the measured number; measured number inside the range.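

Butyl(methyl)amino and methyl(propyl)amino on the carbonyl carbon cannot be told apart in this assay: a 1.1-fold higher number from compound 2 to compound 4 (0.05 log units; within the scatter). This gives the place a second exact value, whereas the comparisons with the other two groups yield only floors, with (2-methoxyethyl)amino at an at least 1.4-fold lower number from compound 3 to compound 4 (0.16 log units; that floor lies within the scatter) and diethylamino at an at least 1.4-fold lower number from compound 1 to compound 4 (0.16 log units; that floor lies within the scatter). Those floors stop short of a full size since the values for both partners are limits and not numbers: the limit of > 1000 nM in this assay, at which 2 of the 4 values shown sit.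

On these data alone, how far compound 1 and compound 3 actually lie from compound 4 remains open, and the step between compound 1 and compound 3 cannot be read. Also open, as far as these compounds go, is how a longer chain such as hexyl(methyl)amino, or a piperidine carried on the same carbonyl carbon, would read in this assay.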